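A few compounds are considered here, and "the series" means these few. Any claim that something is new, unique, unknown or untested is made for them only; others in the source may bear on it.

Compound 1 `O[C@@H]1[C@H](O)[C@@H]2C[C@@H]2[C@H]1n1cnc2c(NC3CCC3)nc(Cl)nc21`: 51.6 nM
Compound 2 `O[C@@H]1[C@H](O)[C@@H]2C[C@@H]2[C@H]1n1cnc2c(NC3CCCCCCC3)nc(Cl)nc21`: 760 nM
Compound 3 `O[C@@H]1[C@H](O)[C@@H]2C[C@@H]2[C@H]1n1cnc2c(NCc3ccccc3F)nc(Cl)nc21`: 4790 nM

In an assay on CHO cells for displacement of a labelled ligand from adenosine receptor A1 (Homo sapiens), read by scintillation counting, with a stated time of 60 min (on this read-out higher numbers stand for weaker inhibition and lower numbers for stronger inhibition), compound 3 gives the highest number of the three measured: the steps of a 93-fold higher number from compound 1 to compound 3 (1.97 log units; beyond the scatter) and a 6.3-fold higher number from compound 2 to compound 3 (0.80 log units; beyond the scatter) both lie beyond the scatter, so compound 3 is the weakest inhibitor shown. Compound 4 `O[C@@H]1[C@H](O)[C@@H]2C[C@@H]2[C@H]1n1cnc2c(NCc3cc(F)ccc3F)nc(Cl)nc21` differs from compound 3 by fluoro in place of hydrogen on an aromatic carbon. Going by the values given here, no measured step touches the six-membered aromatic ring of carbon only; a 15-fold higher number from compound 1 to compound 2 (1.17 log units; beyond the scatter), a 93-fold higher number from compound 1 to compound 3 (1.97 log units; beyond the scatter) and a 6.3-fold higher number from compound 2 to compound 3 (0.80 log units; beyond the scatter) all exchange the whole group on the ring nitrogen. The data therefore give no direct guide to the added fluoro, and a step within the scatter is expected in this assay. Compound 4 is expected to give about 5000 nM (range 1800 nM to 14000 nM), an estimated step of a 1.0-fold higher number from compound 3 to compound 4 (0.02 log units; within the scatter).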

Compound 4, inhibition constant: 1260 nM
Estimate against measurement, compound 4: 4.0-fold (0.60 log units) above; the whole stated range lies above it.
By their numbers in this assay, from the lowest: compound 1; then compounds 2 and 4 (each within the scatter of the next); then compound 3.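

In this assay, fluoro in place of hydrogen on the six-membered aromatic ring, meta to a large group and para to a fluoro group, is the first change shown on that ring, and a single added atom there moves the number (a 3.8-fold lower number from compound 3 to compound 4 (0.58 log units; beyond the scatter)). The 2,5-difluorobenzyl group is within the scatter of cyclooctyl (a 1.7-fold higher number from compound 2 to compound 4 (0.22 log units; within the scatter)), yet still far from cyclobutyl (a 24-fold higher number from compound 1 to compound 4 (1.39 log units; beyond the scatter)). Nothing measured here accounts for the effect of the added fluoro.

The compounds shown leave open whether chloro, methyl or methoxy on this same aromatic carbon would move the number as fluoro does. They also leave open whether the step carries over to a plain benzyl group.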